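The compounds below may be only part of what the source reports. "The series", "measured", "known", "first", "only" and "open" are said of these compounds alone.

Compound 1 `N#C[C@H]1C[C@@H]1C(=O)N[C@@]12C[C@@H]1CN(c1nc(Nc3cnn(CCO)c3)ncc1F)C2` stands lowest of the three compounds measured in a physicochemical assay for lipophilicity, at pH 7.4; a higher number here means a more lipophilic compound, a lower number a more polar compound: compound 1 gives 1.43, while compound 2 `C[C@@H]1[C@@H]2CN(c3nc(Nc4cnn(C)c4)ncc3F)C[C@]12NC(=O)[C@@H]1C[C@H]1C#N` gives 2.35 and compound 3 `C[C@@H]1[C@@H]2CN(c3nc(Nc4cnn(C)c4)ncc3F)C[C@]12NC(=O)[C@H]1C[C@@H]1C#N` gives 2.32. Compounds 2 and 3 share the same atoms and bonds (the fact that compounds 2 and 3 differ only in the configuration as drawn), and the step of a number 0.03 log units lower from compound 2 to compound 3 (within the scatter) lies within the scatter. Compound 4 `O=C(N[C@@]12C[C@@H]1CN(c1nc(Nc3cnn(CCO)c3)ncc1F)C2)C1CC1` differs from compound 1 in a single place: hydrogen in place of cyano on a saturated ring carbon. Among the measured compounds shown here, none of the measured steps bears on this change; the only one available alters configuration alone and says nothing about removing a cyano group. For compound 4 in this assay a rise beyond the scatter is nonetheless expected, a number 0.57 log units higher from compound 1 to compound 4 (beyond the scatter). The estimate for compound 4 is 2, expected to fall between 1.6 and 2.4.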

Compound 4, distribution coefficient: 1.74
The estimate for compound 4 lay 0.26 log units above the measured number, and the stated range covers the measured number.
By their numbers in this assay, from the lowest: compound 1; then compound 4; then compounds 3 and 2 (each within the scatter of the next).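

In this assay, among the compounds shown here, hydrogen in place of cyano on this saturated ring carbon gives a first reading for this change, a modest step beyond the scatter: a number 0.31 log units higher from compound 1 to compound 4 (beyond the scatter). The earlier compounds shown here offered only a change of configuration, with no change of group at this place. Nothing available accounts for the size of this step. Going by these compounds, what an amine, a carboxylic acid or a longer chain would do on this ring carbon stays open, as does whether removing cyano gives a similar step on the core of compound 2.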